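The source may hold more compounds than are shown below. What is called first, only, known or untested is meant among the compounds shown, and "the series" means these compounds.

Measured compounds:
- compound 2 `CC(C)=CCOc1cc(Nc2ncccn2)ccc1Cl`: in an ADME assay on MT2 cells (Homo sapiens) for cytotoxicity (a lower number here means that less compound is tolerated, a higher number that more compound is tolerated), compound 2 gives 2500 nM
- compound 1 `COc1ccnc(Nc2ccc(Cl)c(OCC=C(C)C)c2)n1`: in this assay compound 1 gives 9000 nM

Going by the values given here, compound 2 holds the lowest of the two numbers in this assay; the only neighbour is compound 1, which sits higher by a 3.6-fold lower number from compound 1 to compound 2 (0.56 log units; beyond the scatter) read in the other direction, a gap beyond the scatter. Among the compounds with values here, that single step, hydrogen in place of methoxy on an aromatic carbon, is the one piece of evidence bearing on the next change.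

Compound 3 `CCc1ccnc(Nc2ccc(Cl)c(OCC=C(C)C)c2)n1` is not yet measured. It differs from compound 2 by ethyl in place of hydrogen on an aromatic carbon, the ethyl entering on an aromatic carbon of a six-membered aromatic ring with 2 nitrogen, next to the ring nitrogen, meta to a large group and opposite the ring nitrogen. Compound 1 carries its methoxy on the same kind of carbon, and removing it gave a 3.6-fold lower number from compound 1 to compound 2 (0.56 log units; beyond the scatter). Putting a small group back onto that carbon is therefore expected to move the number upward by a modest step, a 2.4-fold higher number from compound 2 to compound 3 (0.38 log units; beyond the scatter), though ethyl and methoxy are not the same group and the size is uncertain. For compound 3 the estimate in this assay is 6000 nM, within 2500 nM to 15000 nM.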

Compound 3, half-maximal cytotoxic concentration: 330 nM
Beside the measured number, compound 3's estimate is 18-fold (1.26 log units) above it; measured number outside the range, below it.
By their numbers in this assay, from the lowest: compound 3; then compound 2; then compound 1.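

In this assay, filling this carbon of the six-membered aromatic ring with 2 nitrogen does not set the direction of the change: ethyl in place of hydrogen gives a 7.6-fold lower number from compound 2 to compound 3 (0.88 log units; beyond the scatter), whereas compound 1, with methoxy on the same carbon, stands above compound 2. The outcome therefore depends on which group enters, and ethyl in place of methoxy gives a 27-fold lower number from compound 1 to compound 3 (1.44 log units; beyond the scatter), the widest step among the three compounds, with the hydrogen compound lying between the two substituted ones. Nothing on hand accounts for ethyl and methoxy moving the number in opposite directions.

Still open, on these data alone, is whether a methyl group would give a number between those of hydrogen and ethyl, and whether a longer chain such as propyl would take the number lower still, or whether an amine or a hydroxyl on this carbon would follow methoxy instead. As far as these compounds go, it is equally open whether the ethyl step would keep its size with the chlorine or the 3-methylbut-2-enyl ether of the shared core replaced.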